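The source may report more compounds than this note shows. Statements on the series, on what has been measured and on what is new or still open speak of the compounds shown alone.

Working notes on the series.

Three compounds have numbers in an assay on membranes from brain for binding affinity to adenosine receptor A1 (Rattus norvegicus), read by radioligand binding; a lower number here means a stronger inhibitor, a higher number a weaker inhibitor. Compound 1 `Cc1nn(C)c2c(O)ncnc12` is the small bicyclic member; in this assay compound 1 gives 20100 nM. Compound 2 `Cc1ccc(-c2nc(O)c3c(n2)c(C)nn3C)cc1` carries a methylphenyl group on a related bicyclic core; in this assay compound 2 gives 400 nM. Compound 3 `Cn1c(=O)c2nc(-c3cccc([N+](=O)[O-])c3)[nH]c2n(C)c1=O` has a different core with a nitrophenyl group; in this assay compound 3 gives 50 nM.

Compound 3 stands at the lowest of the three numbers. The nearest number is that of compound 2, and the gap between the two lies beyond the scatter; the furthest is that of compound 1, again beyond the scatter. Going by the values given here, no single-point step between any two measured compounds is available, so nothing can be said about the effect of any one group from measured pairs alone.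

Compound 4 `Cn1c(=O)c2nc(-c3cccc(N)c3)[nH]c2n(C)c1=O` is not yet measured. It differs from compound 3 in one place: amino in place of nitro on an aromatic carbon. Among the compounds with values here, no measured pair shows this change, so the expectation rests on the general run of the numbers. The step is expected to be small, weakening if anything, and is estimated at a 1.6-fold higher number from compound 3 to compound 4 (0.20 log units; within the scatter). For compound 4 in this assay the estimate is 80 nM, within a range from 20 nM to 300 nM.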

Compound 4, half-maximal inhibitory concentration: 10 nM
Compound 4: the middle estimate sits 8.0-fold (0.90 log units) above what was measured; the measured number lies below the stated range.
By their numbers in this assay, from the lowest: compound 4; then compound 3; then compound 2; then compound 1.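

In this assay the series now has its first step at a single place: amino in place of nitro, on the six-membered aromatic ring of carbon only and meta to a large group, gives a 5.0-fold lower number from compound 3 to compound 4 (0.70 log units; beyond the scatter) and so shows that the number responds to the group held at this position. The change removes a group of 3 heavy atoms with 0 hydrogen-bond donors and brings in a group of 1 heavy atom with 1 hydrogen-bond donor, so at least on this core the smaller amino group does not cost affinity. Nothing on hand separates the loss of heavy atoms, the gain of the donor or any other difference between the two groups as the source of the step.

With a single pair, the trend at this position remains undefined: a hydroxyl, a methoxy group or an acetamide at the same place would show whether the step follows the donor, the size of the group or neither. As far as these compounds go, it also remains open whether amino in place of nitro would give a similar step on the core of compound 2, or whether the step belongs to the core shared by compound 3 and compound 4 alone.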